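Adding a Bromine to the Most Active Chalcone

The source may hold more compounds than are shown below. What is called first, only, known or untested is meant among the compounds shown, and "the series" means these compounds.

Three chalcones have been tested in a functional assay on PC-3 cells (Homo sapiens), read by fluorescence and BrdU incorporation, with a stated time of 48 h, tested at 25 uM; a lower number here means a stronger effect, a higher number a weaker effect of the compound at the concentration tested. Compound 1 `COc1cc(O)c(C(=O)/C=C/c2ccc(F)cc2)c(OC)c1` gives 34%, and compound 3 `COc1cc(O)c(C(=O)/C=C/c2ccccc2OC)c(OC)c1` gives 24%. Compound 2 `COc1cc(OC)c(C(=O)/C=C/c2ccccc2)c(OC)c1` gives 1.7%, the lowest of the three numbers and therefore the strongest effect; its gaps to compound 3 and to compound 1 both lie beyond the usual scatter. Compound 4 `COc1cc(OC)c(C(=O)/C=C/c2ccc(Br)cc2)c(OC)c1` has not yet been measured. It differs from compound 2 by a single change: bromo in place of hydrogen on an aromatic carbon. Within the data shown here, no measured pair shows this exact change, so its size is uncertain. The expected step of a number 8.3 percentage points higher from compound 2 to compound 4 (within the scatter) in this assay is small and upward, possibly not beyond the scatter. Compound 4 is estimated at 10%, within a range from 1% to 35%.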

Compound 4, a percentage reported as activity, at one concentration (the size of the read-out at that concentration, not a potency): 0.4%
Estimate against measurement, compound 4: 9.6 percentage points above; the measured number lies below the stated range.
By their numbers in this assay, from the lowest: compounds 4 and 2 (each within the scatter of the next); then compounds 3 and 1 (each within the scatter of the next).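

In this assay, going from phenyl to 4-bromophenyl gives a number 1.3 percentage points lower from compound 2 to compound 4 (within the scatter). The carbon para to a large group therefore takes a bromo in place of hydrogen with no measurable change in the read-out, and compound 4 stays level with compound 2 . Nothing available here explains this result.

Still open, going by these compounds, is whether an amine or a carboxylic acid at the same carbon would leave the read-out equally unchanged. Whether a bromo on another carbon of that ring would behave alike is also unknown.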